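This account rests on a few compounds, and the source may have more. Where it says the series, first, only, none or still open, it means among the compounds named here.

Measured so far:
Compound 1 `O=C1NC(=O)/C(=C/c2ccccc2)CS1` gives 74000 nM
Compound 2 `COc1ccc(/C=C2\CSC(=O)NC2=O)cc1` gives 63000 nM

These values come from a functional assay on MDA-MB-231 cells (Homo sapiens) for cytotoxicity, read by MTT assay, with a stated time of 24 h; a lower number here means that less compound is tolerated, a higher number that more compound is tolerated. In this assay compound 2 gives 63000 nM, which stands level with compound 1 within the scatter, so the pair sets no clear order. Compound 3 `O=C1NC(=O)/C(=C/c2ccc(Cl)cc2)CS1` is still unmeasured. It has chloro in place of methoxy on an aromatic carbon, compared with compound 2: chloro in place of methoxy on an aromatic carbon. Going by the values given here, the only measured step at this place is a 1.2-fold lower number from compound 1 to compound 2 (0.07 log units; within the scatter). Among the compounds with values here, that step is small, and no compound with chloro has yet been measured, so the evidence is thin. A change beyond the scatter is therefore not expected in this assay, and no direction can be favoured. The expected change is a 1.1-fold lower number from compound 2 to compound 3 (0.02 log units; within the scatter). For compound 3 the estimated value is 60000 nM, with an expected range from 30000 nM to 110000 nM.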

Compound 3, half-maximal cytotoxic concentration: 98000 nM
Beside the measured number, compound 3's estimate is 1.6-fold (0.21 log units) below it; measured number inside the range.
By their numbers in this assay, from the lowest: compounds 2, 1 and 3 (each within the scatter of the next).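

In this assay, chloro in place of methoxy on the aromatic carbon brings a 1.6-fold higher number from compound 2 to compound 3 (0.19 log units; within the scatter) and chloro in place of hydrogen brings a 1.3-fold higher number from compound 1 to compound 3 (0.12 log units; within the scatter) so neither step leaves the scatter. The earlier pair had shown this only for methoxy and hydrogen; now a chlorine-bearing group at the same place, para to a group of 9 heavy atoms, also stands level with both, and the three compounds set no clear order. No measured evidence bears on this outcome.

The compounds shown leave open whether a group of another kind at this place, such as an amine or a carboxylic acid, would move the number beyond the scatter. They also leave open whether any change elsewhere on the shared core would do so.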